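Methyl for methoxy on the aryl amide of compound 3

The compounds below may be only part of what the source reports. "The series", "measured", "known", "first", "only" and "open" are said of these compounds alone.

Of the compounds shown here, three share one core and have been measured in a functional assay on HEK293 cells for agonist activity at D(4) dopamine receptor (Homo sapiens), read by FLIPR; a lower number here means that less compound is needed, a higher number that more compound is needed for the effect. Compound 1 `O=C(NCN1CCC(c2cccc[n+]2[O-])CC1)c1cnccc1Cl` gives 1290 nM. Compound 2 `Cc1cc(C)cc(C(=O)NCN2CCC(c3cccc[n+]3[O-])CC2)c1` gives 90 nM. Compound 3 `COc1cc(C(=O)NCN2CCC(c3cccc[n+]3[O-])CC2)ccc1Cl` gives 159 nM, the second highest of the three numbers; its gap to compound 2 lies within the scatter, while compound 1 sits beyond the scatter above it.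

Compound 4 `Cc1cc(C(=O)NCN2CCC(c3cccc[n+]3[O-])CC2)ccc1Cl` differs from compound 3 in one place: methyl in place of methoxy on an aromatic carbon. Within the data shown here, no measured step describes this change. Among the measured compounds shown here, the only step on record, a 14-fold lower number from compound 1 to compound 2 (1.16 log units; beyond the scatter), swaps the whole aryl group on the carbonyl carbon and says nothing about a methoxy-to-methyl exchange. Compound 2 and compound 3, which carry different substituents on the same ring, sit within the scatter of each other, so nothing points to a large effect of small substituent changes here.

Compound 4 is therefore expected to stay close to compound 3, with a 1.1-fold lower number from compound 3 to compound 4 (0.03 log units; within the scatter) as the expected step. The estimate for compound 4 in this assay is 150 nM, within 60 nM to 400 nM.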

Compound 4, half-maximal effective concentration: 2460 nM
Beside the measured number, compound 4's estimate is 16-fold (1.21 log units) below it; measured number outside the range, above it.
By their numbers in this assay, from the lowest: compounds 2 and 3 (each within the scatter of the next); then compounds 1 and 4 (each within the scatter of the next).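

At this position, ortho to a chloro group, methyl in place of methoxy is no minor exchange in this assay (a 15-fold higher number from compound 3 to compound 4 (1.19 log units; beyond the scatter)), although only one heavy atom, the oxygen, separates the two groups. Methyl on the ring does not by itself set the number: the 4-chloro-3-methylphenyl of compound 4 stands far from the 3,5-dimethylphenyl of compound 2 (a 27-fold higher number from compound 2 to compound 4 (1.44 log units; beyond the scatter)) and within the scatter of the 4-chloropyridin-3-yl of compound 1 (a 1.9-fold higher number from compound 1 to compound 4 (0.28 log units; within the scatter)). No measurement on record accounts for the size of the step from methoxy to methyl.

Going by these compounds, how a hydroxy, an ethoxy or an amine would read at this position stays open. Also open, on these data alone, is whether the methoxy-to-methyl step would keep its size without the chloro group.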